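Chlorine on the benzimidazole arm of a triazole-linked aminoquinoline

The compounds below may be only part of what the source reports. "The series", "measured", "known", "first", "only" and "open" are said of these compounds alone.

Compound 1 `CN(CCNCc1cn(-c2ccccc2)nn1)CCNc1ccnc2cc(Cl)ccc12`: 25000 nM
Compound 2 `CN(CCNCc1cn(-c2ccc(Cl)cc2)nn1)CCNc1ccnc2cc(Cl)ccc12`: 14000 nM
Compound 3 `CN(CCNCc1cn(Cc2nc3ccccc3[nH]2)nn1)CCNc1ccnc2cc(Cl)ccc12`: 120000 nM

Three compounds share a chloroquinoline-amine core and a triazole carrying a variable group on its ring nitrogen; they were tested in a functional assay on NCI-H460 cells (Homo sapiens) for antiproliferative activity, read by sulforhodamine B assay, with a stated time of 72 h; a higher number here means a weaker inhibitor, a lower number a stronger inhibitor. Compound 1 gives 25000 nM, compound 2 gives 14000 nM, and compound 3 gives 120000 nM. The change from compound 1 to compound 2 is chloro in place of hydrogen on an aromatic carbon, and it made a 1.8-fold lower number from compound 1 to compound 2 (0.25 log units; within the scatter). The cores of compound 1 and compound 3 differ by (1H-benzimidazol-2-yl)methyl in place of phenyl on an aromatic nitrogen, a change that made a 4.8-fold higher number from compound 1 to compound 3 (0.68 log units; beyond the scatter).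

Compound 4 `CN(CCNCc1cn(Cc2nc3cc(Cl)ccc3[nH]2)nn1)CCNc1ccnc2cc(Cl)ccc12` is not yet measured. Its change from compound 3 is chloro in place of hydrogen on an aromatic carbon. Among the compounds with values here, this is the same kind of change as the one from compound 1 to compound 2, but not the same: in compound 2 the chloro sits para to a large group on a ring of carbon only, whereas in compound 4 it sits on a ring that is part of a fused or bridged system of two rings, meta to a fused ring and para to a fused ring. Because the earlier step of a 1.8-fold lower number from compound 1 to compound 2 (0.25 log units; within the scatter) stayed within the scatter, compound 4 is expected to give 75000 nM, between 30000 nM and 180000 nM. The step expected from compound 3 to compound 4 is a 1.6-fold lower number from compound 3 to compound 4 (0.20 log units; within the scatter).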

Compound 4, half-maximal inhibitory concentration: 59000 nM
Beside the measured number, compound 4's estimate is 1.3-fold (0.10 log units) above it; low and high end bracket the measured number.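

In this assay, chloro in place of hydrogen on an aromatic carbon gave steps of similar size on the two cores, and the gap between them does not separate the cores: the same change on two cores in this assay, a 1.8-fold lower number (0.25 log units; within the scatter) from compound 1 to compound 2 and a 2.0-fold lower number (0.31 log units; beyond the scatter) from compound 3 to compound 4, 1.1-fold (0.06 log units) apart, within the scatter of two such steps

Even so, the new step, a 2.0-fold lower number from compound 3 to compound 4 (0.31 log units; beyond the scatter), leaves the chlorinated arm behind the aryl groups, with a 4.2-fold higher number from compound 2 to compound 4 (0.62 log units; beyond the scatter) and a 2.4-fold higher number from compound 1 to compound 4 (0.37 log units; beyond the scatter).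

Within the data shown here, this rests on only two pairs, with the chloro on a ring of carbon only in compound 2 and on a fused ring system in compound 4, so it does not show that the change would carry to other cores or other places on these rings.

As far as these compounds go, it remains open whether a fluoro, a methoxy or a carboxylic acid in place of the chloro would shift the number in the same direction on both cores. Also open, from the compounds shown here alone, is how a longer chain in place of the methyl link in (5-chloro-1H-benzimidazol-2-yl)methyl would behave.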